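A Bromophenyl Swap on the Triazole Nitrogen

The compounds below may be only part of what the source reports. "The series", "measured", "known", "first", "only" and "open" are said of these compounds alone.

The measured compounds:
- compound 1 `COc1cc2c(Oc3ccc(NC(=O)c4nnn(-c5ccc(C)cc5)c4C(F)(F)F)cc3F)ccnc2cc1OCCCN1CCCC1`: 790 nM
- compound 2 `COc1cc2c(Oc3ccc(NC(=O)c4nnn(-c5ccc(F)c(F)c5)c4C(F)(F)F)cc3F)ccnc2cc1OCCCN1CCCCC1`: 210 nM
- compound 3 `COc1cc2c(Oc3ccc(NC(=O)c4nnn(-c5ccc(C)cc5)c4C(F)(F)F)cc3F)ccnc2cc1OCCCN1CCC(C)CC1`: 1250 nM

All three share one core and differ only in the ring at the end of the side chain and in the aryl group on the triazole nitrogen. In a functional assay on NCI-H460 cells (Homo sapiens) for cytotoxicity, read by MTT assay, with a stated time of 72 h (a lower number here means a stronger inhibitor, a higher number a weaker inhibitor), compound 3 gives the highest of the three numbers. Its nearest neighbour is compound 1, and the step of a 1.6-fold higher number from compound 1 to compound 3 (0.20 log units; within the scatter) lies within the scatter, so the two are not distinguishable. Compound 2 stands further away, with a number that is beyond the scatter lower than that of compound 3; but compound 2 differs from compound 3 in two places, so its value alone does not tell which change is responsible.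

Compound 4 `COc1cc2c(Oc3ccc(NC(=O)c4nnn(-c5cccc(Br)c5)c4C(F)(F)F)cc3F)ccnc2cc1OCCCN1CCC(C)CC1` keeps everything of compound 3 except for one change: 3-bromophenyl in place of 4-methylphenyl on an aromatic nitrogen. Going by the values given here, none of the measured steps touches this aryl group, so no direct guide exists. Compound 2, which carries a halogenated aryl group and a lower number, hints that a change on this ring need not hurt, but it is not a clean comparison. The expected step of a 1.4-fold lower number from compound 3 to compound 4 (0.14 log units; within the scatter) is therefore set small, with wide uncertainty. Compound 4 is estimated at 900 nM, within 350 nM to 2500 nM.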

Compound 4, half-maximal inhibitory concentration: 450 nM
Estimate against measurement, compound 4: 2.0-fold (0.30 log units) above; measured number inside the range.
By their numbers in this assay, from the lowest: compound 2; then compounds 4, 1 and 3 (each within the scatter of the next, the first and the last beyond it).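

In this assay, going by these compounds alone, the change gives a 2.8-fold lower number from compound 3 to compound 4 (0.44 log units; beyond the scatter), the first single-place evidence that the aryl group on the aromatic nitrogen can move the number beyond the scatter, whereas the only earlier single-place step, a 1.6-fold higher number from compound 1 to compound 3 (0.20 log units; within the scatter), made in the ring at the end of the side chain, stayed within it. The group that leaves and the group that enters match in heavy-atom count, in having one six-membered aromatic ring of carbon only, and in having no hydrogen-bond donors or acceptors, so these counts do not separate them; what differs is the substituent, methyl or bromine, and its position on the ring. No measurement here explains the shift in the number.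

With both the substituent and its position changing in one step, the compounds shown leave open which of the two matters, a question that 4-bromophenyl and 3-methylphenyl on the same nitrogen could help to settle. They also leave open whether 3-bromophenyl would give a similar step with pyrrolidin-1-yl or piperidin-1-yl at the end of the side chain.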